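A few compounds are considered here, and "the series" means these few. Any claim that something is new, unique, unknown or untested is made for them only; others in the source may bear on it.

Measured compounds:
compound 1, `O=C(COc1ccncc1-c1ccc2ccccc2c1)N1CCOCC1`, giving 9%
compound 2, `NC(=O)/C=C/c1ccncc1Nc1ccc(F)cc1`, giving 70%

Of the compounds shown here, two have been measured in an assay on a protein complex for inhibition of CDK8/Cyclin C (Homo sapiens), with a stated time of 1 h, tested at 10 uM; on this read-out lower numbers stand for less inhibition and higher numbers for more inhibition at the one concentration tested (going by the name of the read-out). Compound 1 stands lowest of the two numbers; its nearest neighbour is compound 2, whose value lies higher by a gap beyond the usual scatter of repeated measurements. Within the data shown here, the two structures differ in more than one place, so no single step can be traced between them, and the pair shows only that compound 2 sits well above compound 1 in this assay.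

Compound 3, `COC(=O)COc1ccncc1-c1ccc2ccccc2c1`, has not yet been measured. It is reached from compound 1 by one change, the (methoxy in place of morpholin-4-yl on a carbonyl carbon). The shared core of compound 1 and the naphthalene-bearing side are kept intact, and the change touches only the carbonyl substituent.

Among the measured compounds shown here, no measured step of this kind exists among the compounds here, so the expectation rests on compound 1 alone, whose value of 9% is the anchor. The step expected is a number 1 percentage points higher from compound 1 to compound 3 (within the scatter), none beyond the scatter. Compound 3 is expected to give 10%, with a range from 0% to 30%.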

Compound 3, a percentage reported as inhibition, at one concentration (the size of the read-out at that concentration, not a potency): 11%
For compound 3 the middle estimate is 1 percentage points below the measured one, within the range that was stated.
By their numbers in this assay, from the lowest: compounds 1 and 3 (each within the scatter of the next); then compound 2.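

In this assay, putting methoxy in place of morpholin-4-yl on a carbonyl carbon gives a number 2 percentage points higher from compound 1 to compound 3 (within the scatter), so this read-out does not separate the two groups at this position. The change removes a six-membered non-aromatic ring of 6 heavy atoms and leaves a group of 2 heavy atoms on the same carbonyl carbon, whose other neighbour is a saturated chain carbon, yet the values of the two compounds stay within the scatter of each other; the low number of compound 1 therefore does not depend on the morpholin-4-yl ring being present. No independent evidence bears on why these two groups give such similar numbers.

The compounds shown leave open whether any group on this carbonyl carbon can lift the number beyond the scatter, for instance a free carboxylic acid, a primary amide or a longer alkoxy chain such as butoxy. They also leave open whether a change elsewhere, such as an amine on the naphthalene-bearing side, would matter more in this assay than either of the two groups compared here.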